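Acetamido in Place of Hydrogen: Cytotoxicity Outlook

This account rests on a few compounds, and the source may have more. Where it says the series, first, only, none or still open, it means among the compounds named here.

Compound 1 `S=C(Nc1ccccc1)Nc1ccc2[nH]ccc2c1` has been tested in an ADME assay on CHO-K1 cells (Cricetulus griseus) for cytotoxicity, read by MTT assay, with a stated time of 24 h; a higher number here means that more compound is tolerated, a lower number that less compound is tolerated. In this assay compound 1 gives 337000 nM, the highest of the two numbers seen so far. For the measured compounds named here, its nearest neighbour, compound 2 `S=C(Nc1ccc(Oc2ccccc2)cc1)Nc1ccc2[nH]ccc2c1`, gives 36000 nM; the single change between them, a 9.4-fold lower number from compound 1 to compound 2 (0.97 log units; beyond the scatter), shows that adding a group at that spot lowered the tolerated concentration. Compound 3 `CC(=O)Nc1ccc(NC(=S)Nc2ccc3[nH]ccc3c2)cc1` differs from compound 1 by acetamido in place of hydrogen on an aromatic carbon. Only the phenoxy step bears on this change, and a smaller drop in the same direction is expected, a 2.2-fold lower number from compound 1 to compound 3 (0.35 log units; beyond the scatter). Compound 3 is therefore estimated at 150000 nM, in a range from 50000 nM to 400000 nM.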

Compound 3, concentration lethal to 50% of the cells: 1040000 nM
Beside the measured number, compound 3's estimate is 6.9-fold (0.84 log units) below it; measured number outside the range, above it.
By their numbers in this assay, from the lowest: compound 2; then compound 1; then compound 3.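

Acetamido and phenoxy push the number in opposite directions at this position: acetamido gives a 3.1-fold higher number from compound 1 to compound 3 (0.49 log units; beyond the scatter), so adding a group here does not always lower the tolerated concentration. The outcome depends on which group is present, and replacing phenoxy with acetamido gives a 29-fold higher number from compound 2 to compound 3 (1.46 log units; beyond the scatter), the largest step among these compounds. Nothing available explains this difference.

Only these two groups are shown at this position. From the compounds shown here alone, whether an amine, a carboxylic acid or a longer chain would land nearer compound 2 or compound 3 remains open.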